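The compounds below may be only part of what the source reports. "The series", "measured", "known", "first", "only" and "open" are said of these compounds alone.

Compound 3 `COc1ccc(-c2ccc3c(NCCCNCc4cc(F)ccc4OC)ccnc3c2)cc1` sits level with its two neighbours on the permeability numbers. In an ADME assay for permeability, using PAMPA, with a stated time of 30 min, at pH 7.4 (a higher number here means that the compound crosses the layer faster, a lower number that the compound crosses the layer more slowly), compound 3 gives 237 10^-6 cm/s; compound 1 `COc1ccc(-c2ccc3c(NCCCNCc4cccc(OC)c4O)ccnc3c2)cc1` gives 237 10^-6 cm/s and compound 2 `COc1ccc(-c2ccc3c(NCCCNCc4ccco4)ccnc3c2)cc1` gives 237 10^-6 cm/s. The recorded steps among these three, no change at the digits printed from compound 1 to compound 2 (within the scatter), no change at the digits printed from compound 1 to compound 3 (within the scatter) and no change at the digits printed from compound 2 to compound 3 (within the scatter), all concern the group on the saturated chain carbon bound to an amine nitrogen and all stay within the scatter.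

Compound 4 `COc1ccc(F)cc1CNCCCNc1ccnc2cc(Oc3ccc(Cl)cc3)ccc12` differs from compound 3 elsewhere: 4-chlorophenoxy in place of 4-methoxyphenyl on an aromatic carbon. Among the compounds with values here, none of the measured steps touches this aromatic carbon, so there is no direct precedent for the change. What the data do show is that the three measured compounds, which share the core of compound 3 and differ only on the chain, all return the same reading in this assay. On that basis compound 4 is expected to show no movement beyond the scatter, a step of no change at the digits printed from compound 3 to compound 4 (within the scatter). The estimate for compound 4 in this assay is therefore 237 10^-6 cm/s, with a range from 120 10^-6 cm/s to 300 10^-6 cm/s.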

Compound 4, apparent permeability: 317 10^-6 cm/s
Compound 4: middle estimate off by 1.3-fold (0.13 log units), on the low side; measured number above the stated range.
By their numbers in this assay, from the lowest: compounds 1, 2, 3 and 4 (each within the scatter of the next).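

Within the data shown here, the earlier compounds differed only in the group on the chain, so this is the first reading at this aromatic carbon of the shared core. In this assay, putting 4-chlorophenoxy in place of 4-methoxyphenyl gives a 1.3-fold higher number from compound 3 to compound 4 (0.13 log units; within the scatter), which shows that this exchange, between two groups with the same count of heavy atoms and hydrogen-bond acceptors, stays as close to compound 3 as the chain exchanges stayed to one another. Nothing at hand bears on what lies behind this small step.

The compounds shown leave open whether 4-chlorophenyl, 4-methoxyphenoxy or a group of a different kind here, such as a morpholine or a carboxylic acid, would also stay within the scatter of compound 3 in this assay. They also leave open whether the furan-2-yl and 2-hydroxy-3-methoxyphenyl chain groups would read the same alongside 4-chlorophenoxy.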